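Swapping 3-methoxyphenoxy for 4-fluorophenoxy in compound 3

A few compounds are considered here, and "the series" means these few. Any claim that something is new, unique, unknown or untested is made for them only; others in the source may bear on it.

Measured so far in a physicochemical assay for acid dissociation, are three compounds:

- compound 1 `COc1ccc(-c2ccc3c(NCCCNCc4cccc(OC)c4O)ccnc3c2)cc1` gives 9.47
- compound 2 `COc1cccc(Oc2ccc3c(NCCCNCc4ccco4)ccnc3c2)c1` gives 9.28
- compound 3 `COc1cccc(Oc2ccc3c(NCCCNCc4cccc(OC)c4O)ccnc3c2)c1` gives 9.28

Compound 3 stands level with compound 2 at the digits shown, and compound 1 lies within the scatter of compound 3. Compound 4 `COc1cccc(CNCCCNc2ccnc3cc(Oc4ccc(F)cc4)ccc23)c1O` carries 4-fluorophenyl in place of 3-methoxyphenyl on an oxygen on an aromatic ring so that 3-methoxyphenoxy becomes 4-fluorophenoxy.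

Two measured steps offer indirect guidance. One is a number 0.19 log units lower from compound 1 to compound 3 (within the scatter) where 3-methoxyphenoxy replaces 4-methoxyphenyl on an aromatic carbon. The other is no change at the digits printed from compound 2 to compound 3 (within the scatter) where 2-hydroxy-3-methoxyphenyl replaces furan-2-yl on a saturated chain carbon bound to an amine nitrogen. For the measured compounds named here, neither is the exchange made here, and no measured compound carries 4-fluorophenyl. Even so, both changes stayed within the scatter, so a similar outcome is expected. The expected size is an estimated a number 0.02 log units higher from compound 3 to compound 4 (within the scatter) and so nothing beyond the scatter, with no firm direction. In this assay the estimate for compound 4 is 9.3 with an expected range from 9 to 9.6 around it.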

Compound 4, acid dissociation constant: 9.28
Compound 4: the middle estimate sits 0.02 log units above what was measured; the range from low to high includes it.
By their numbers in this assay, from the lowest: compounds 2, 3, 4 and 1 (each within the scatter of the next).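

In this assay, for the compounds shown here, the exchange at this oxygen on an aromatic ring gives no change at the digits printed from compound 3 to compound 4 (within the scatter), which is the first direct reading at this place: 3-methoxyphenyl, with its methoxy group, can give way to 4-fluorophenyl, with its fluorine, and the number does not register the exchange. Compound 4 also extends the comparison with compound 1, where replacing 4-methoxyphenyl on an aromatic carbon with 4-fluorophenoxy gives a number 0.19 log units lower from compound 1 to compound 4 (within the scatter), and this matches the earlier a number 0.19 log units lower from compound 1 to compound 3 (within the scatter), so two different phenoxy groups give the same reading against compound 1. Nothing among the available findings explains why the number holds steady across these groups.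

On these data alone, all the groups compared at this oxygen are substituted phenyl rings, so it remains open whether a basic amine, a carboxylic acid or a plain alkyl chain there would move the number beyond the scatter. The compounds shown also leave open whether a fluorine or methoxy group placed elsewhere on the phenyl ring would read the same in this assay.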